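This account rests on a few compounds, and the source may have more. Where it says the series, first, only, none or still open, it means among the compounds named here.

Measured in a functional assay for inhibition, with Homo sapiens as the target; on this read-out higher numbers stand for an effect only at larger amounts of compound and lower numbers for an effect already at smaller amounts:
- Compound 1 `CCC(=O)Nc1ccc(C2=NNC(=O)CC2)cc1`: 0.64 ug/mL
- Compound 2 `CCCC(=O)Nc1ccc(C2=NNC(=O)CC2)cc1`: 1.44 ug/mL
- Compound 3 `CC(=O)Nc1cccc(C2=NNC(=O)CC2)c1`: > 46.4 ug/mL, a limit of the assay and not a number

Of the two actual numbers, compound 2 has the higher, and compound 1 is its nearest neighbour. The next change leads to compound 4 `CCC(Cl)C(=O)Nc1ccc(C2=NNC(=O)CC2)cc1`: chloro in place of hydrogen on a saturated chain carbon bound to a carbonyl carbon and a saturated chain carbon. Among the measured compounds shown here, only one measured step bears on it, and only loosely: a 2.3-fold higher number from compound 1 to compound 2 (0.35 log units; beyond the scatter). That modest step placed methyl, not chloro, on the chain, two bonds along from a carbonyl carbon. A modest step towards a higher number is therefore expected, though its direction is uncertain. The expected change is a 1.7-fold higher number from compound 2 to compound 4 (0.24 log units; within the scatter). Compound 4 is estimated at 2.5 ug/mL, with an expected range from 0.8 ug/mL to 8 ug/mL.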

Compound 4, half-maximal effective concentration: 1.47 ug/mL
Estimate against measurement, compound 4: 1.7-fold (0.23 log units) above, within the range that was stated.
By their numbers in this assay, from the lowest: compound 1; then compounds 2 and 4 (each within the scatter of the next). At a limit, above all of these: compound 3.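

In this assay, chloro in place of hydrogen on a saturated chain carbon bound to a carbonyl carbon and a saturated chain carbon gives a 1.0-fold higher number from compound 2 to compound 4 (0.01 log units; within the scatter), so this position accepts chloro without a change beyond the scatter. Measured against the core of compound 1, the group of 4 heavy atoms on a carbonyl carbon gives a 2.3-fold higher number from compound 1 to compound 4 (0.36 log units; beyond the scatter), and compound 1 keeps the lowest number of the three. No measured property in the data accounts for either step.

Going by these compounds, whether an amine, a hydroxyl group or fluoro at this chain carbon would match chloro remains open. On these data alone, a longer chain on the carbonyl carbon also remains untested in these compounds.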